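This account rests on a few compounds, and the source may have more. Where it says the series, first, only, none or still open, it means among the compounds named here.

The measured compounds:
compound 1, `C=C1C[C@]23C[C@@]1(O)CC[C@H]2c1cc(Br)c(O)c(C)c1[C@@H]3Cn1cc(-c2ccc(C)cc2)nn1`, which in a functional assay on SMMC-7721 cells (Homo sapiens) for cytotoxicity, read by MTT assay, with a stated time of 4 days (on this read-out higher numbers stand for weaker inhibition and lower numbers for stronger inhibition), gives > 20000 nM.
compound 2, `C=C1C[C@]23C[C@@]1(O)CC[C@H]2c1cc(Br)c(O)c(C)c1[C@@H]3Cn1cc(-c2ccccn2)nn1`, which in this assay gives > 20000 nM.

Compound 1 stands only at a limit of this assay, not at a number. Compound 2 stands at a limit as well. Within the data shown here, the one measured step, a step that the two limits leave unreadable from compound 1 to compound 2, cannot be sized, which follows from the limit of > 20000 nM in this assay, at which 2 of the 2 values shown sit.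

The compound still to be measured is compound 3, `C=C1C[C@]23C[C@@]1(O)CC[C@H]2c1ccc(O)c(C)c1[C@@H]3Cn1cc(-c2ccc(C)cc2)nn1`. It differs from compound 1 in one place: hydrogen in place of bromo on an aromatic carbon. The bromo leaves from an aromatic carbon ortho to a hydroxy group and meta to a methyl group, and a hydrogen enters there.

Among the measured compounds shown here, no measured step bears on this change: the only step recorded touches the pyridin-2-yl in place of 4-methylphenyl on a different aromatic carbon, and its size is unreadable. With both measured values sitting at the limit, compound 3 is expected to land near that limit too, estimated at 25000 nM with a range from 8000 nM to 80000 nM. The expected step from compound 1 is therefore a step that the limit leaves unreadable from compound 1 to compound 3, with no direction the data can support.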

Compound 3, half-maximal inhibitory concentration: > 20000 nM
Compound 3: no number, only a limit; the forecaster's own chance of this, stated with the estimate: 70%; the middle value is on the limit's open side.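

In this assay compound 3 gives > 20000 nM, which is a limit of the assay and not a number. Swapping bromo for hydrogen therefore yields no readable step between compound 1 and compound 3, because both stand at the same limit: the limit of > 20000 nM in this assay, at which 3 of the 3 values shown sit.

The compounds shown leave open whether this exchange, or any other on the shared core, changes cytotoxicity at all.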